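Nitro for fluoro on the compound 1 scaffold

The source may hold more compounds than are shown below. What is called first, only, known or untested is meant among the compounds shown, and "the series" means these compounds.

Measured so far:
- compound 1 `Fc1ccccc1C1=NC(c2ccccc2)CO1` gives 3.51
- compound 2 `Fc1cccc(Cl)c1-c1ncco1` gives 1.89
- compound 3 `Fc1cccc(F)c1C1=NC(c2ccccc2)CO1` gives 3.01

In a physicochemical assay for lipophilicity (on this read-out higher numbers stand for higher lipophilicity and lower numbers for lower lipophilicity), compound 1 stands at 3.51 as the highest of the three numbers. Compound 3 is nearest at 3.01 and compound 2 is furthest at 1.89 with both gaps beyond the scatter.

Compound 4 `O=[N+]([O-])c1ccccc1C1=NC(c2ccccc2)CO1` is still unmeasured. It departs from compound 1 by nitro in place of fluoro on an aromatic carbon, ortho to a large group nitro in place of fluoro on an aromatic carbon and the rest of the structure is unchanged.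

Among the measured compounds shown here, only one measured step bears on this change: a number 0.50 log units lower from compound 1 to compound 3 (beyond the scatter) for fluoro in place of hydrogen on an aromatic carbon, which is modest and beyond the scatter. For the measured compounds named here, no measured step involves nitro, so this step offers a guide to size and not a direct precedent. Going by the values given here, compound 2 differs from compound 1 in more than one place and gives no single-change step.

Among the compounds with values here, with compound 3 and a number 0.50 log units lower from compound 1 to compound 3 (beyond the scatter) as the only guide, a modest step towards a lower number is expected in this assay for this exchange. The estimated step is a number 0.41 log units lower from compound 1 to compound 4 (beyond the scatter) with wide margins. For compound 4 the estimated value is 3.1 within an expected range of 2.6 to 3.6 as the working figure.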

Compound 4, partition coefficient: 2.83
Compound 4: the middle estimate sits 0.27 log units above what was measured; low and high end bracket the measured number.
By their numbers in this assay, from the lowest: compound 2; then compounds 4 and 3 (each within the scatter of the next); then compound 1.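

In this assay, among the compounds shown here, the step of a number 0.68 log units lower from compound 1 to compound 4 (beyond the scatter) is the first to replace the fluoro itself on this aromatic carbon, ortho to a large group, whereas the step of a number 0.50 log units lower from compound 1 to compound 3 (beyond the scatter) is a fluoro in place of hydrogen. The fluoro at this position is therefore not required for a number in this range: nitro, with 3 heavy atoms and 2 hydrogen-bond acceptors against 1 heavy atom and 0 hydrogen-bond acceptors for fluoro, moves the read-out by a modest step beyond the scatter, with the rest of compound 1 unchanged. Nothing available accounts for the size or direction of this step.

With nitro as the only replacement for fluoro shown here, a single step cannot establish a trend across groups at this position, so it remains open whether an amine, a carboxylic acid or a methyl group would also give a lower number than compound 1 in this assay. Going by these compounds, it also remains open whether nitro would give a step of similar size on another aromatic carbon or on a different core.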